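Swapping Bromine for Chlorine on a Growth-Inhibition Scaffold

The compounds below may be only part of what the source reports. "The series", "measured", "known", "first", "only" and "open" are said of these compounds alone.

Compound 2 `O=C(Nc1sc2c(c1C(=O)NNc1ccc(Br)cc1)CCCCC2)NS(=O)(=O)c1ccccc1` carries a sulfonylurea on one side of its shared core and, on a carbonyl carbon, a ((4-bromophenyl)amino)amino group. In a functional assay on EKVX cells (Homo sapiens) for inhibition, with a stated time of 48 h (on this read-out lower numbers stand for stronger inhibition of growth and higher numbers for weaker inhibition of growth), compound 2 gives only a limit of > 100000 nM. Compound 1 `CN1CCN(C(=O)c2c(NC(=O)NS(=O)(=O)c3ccccc3)sc3c2CCCCC3)CC1`, which has a 4-methylpiperazin-1-yl group on that same carbonyl carbon instead, likewise gives only a limit of > 100000 nM. The step that the two limits leave unreadable from compound 1 to compound 2 cannot be read because both values sit at the limit of > 100000 nM in this assay, at which 2 of the 2 values shown sit. Compound 3 `O=C(Nc1sc2c(c1C(=O)NNc1ccc(Cl)cc1)CCCCC2)NS(=O)(=O)c1ccccc1` differs from compound 2 by a single exchange, (chloro in place of bromo on an aromatic carbon). Within the data shown here, no measured step bears directly on this change, and neither measured compound offers a number to anchor it. With just one heavy atom swapped, compound 3 is expected to remain at the limit, so the step of a number no higher from compound 2 to compound 3 (the limit leaves the size open) is estimated as none beyond the scatter. For compound 3 the estimate is 100000 nM, within a range of 30000 nM to 300000 nM.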

Compound 3, concentration for 50% growth inhibition: > 100000 nM
Compound 3: only a limit was reported (the forecaster's own chance of this, stated with the estimate: 85%); the middle value lies on the limit itself.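

In this assay, among these compounds, compound 3 gives only the limit > 100000 nM and so no step linking compound 1, compound 2 and compound 3 can be read, because all the values sit at one limit: the limit of > 100000 nM in this assay, at which 3 of the 3 values shown sit. The compounds shown leave open whether chloro and bromo differ at all in this growth inhibition.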